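The compounds below may be only part of what the source reports. "The series", "measured", "known", "first", "only" and "open" are said of these compounds alone.

Working notes on the series. Compound 1 `CC[C@@H](NC(=O)c1ccccc1)C(=O)N1CCC(c2ccc(Cl)cc2)CC1` gives 121 nM in an assay on THP-1 cells for displacement of a labelled ligand from C-C chemokine receptor type 1 (Homo sapiens); on this read-out higher numbers stand for weaker inhibition and lower numbers for stronger inhibition. Compound 2 `CC(C)[C@@H](NC(=O)CCc1ccc(F)cc1)C(=O)N1CCC(c2ccc(Cl)cc2)CC1` gives 70 nM in this assay, and compound 3 `CC(C)C(NC(=O)Oc1ccccc1)C(=O)N1CCC(c2ccc(Cl)cc2)CC1` gives 265 nM. Of the three numbers so far, that of compound 2 is the lowest shown; compound 1 lies within the scatter of it, while the gap to compound 3 is beyond the scatter. Compound 4 `CC(C)[C@@H](NC(=O)c1ccc(F)c(F)c1)C(=O)N1CCC(c2ccc(Cl)cc2)CC1` is not yet measured. The change from compound 2 is 3,4-difluorophenyl in place of 2-(4-fluorophenyl)ethyl on a carbonyl carbon. Among the measured compounds shown here, no step between measured compounds shares this change, and compound 1 with its benzamide does not tell the size either. The step from compound 2 to compound 4 is expected to be small, a 1.6-fold higher number from compound 2 to compound 4 (0.20 log units; within the scatter), and not beyond the scatter. Compound 4 is estimated at 110 nM, with a range from 40 nM to 320 nM.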

Compound 4, half-maximal inhibitory concentration: 14 nM
For compound 4 the middle estimate is 7.9-fold (0.90 log units) above the measured one; measured number below the stated range.
By their numbers in this assay, from the lowest: compound 4; then compounds 2 and 1 (each within the scatter of the next); then compound 3.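

In this assay, 3,4-difluorophenyl in place of 2-(4-fluorophenyl)ethyl on a carbonyl carbon gives a 5.0-fold lower number from compound 2 to compound 4 (0.70 log units; beyond the scatter) and is a step beyond the scatter. This position therefore responds to the group it carries, and an aryl group set directly on the carbonyl carbon is compatible with a lower number. No measurement shown gives a reason for this step. The change replaces the chain and alters the fluorine substitution at once, and the compounds shown do not separate these two parts. From the compounds shown here alone, how an amine or a carboxylic acid on the aromatic ring would fare at this position also remains open.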